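Methyl removal on the ring nitrogen of compound 3

This account rests on a few compounds, and the source may have more. Where it says the series, first, only, none or still open, it means among the compounds named here.

Compound 3 `Cc1cc2c(cn1)c(N)nn2C` gives 3% in an assay on isolated protein for inhibition of serine/threonine-protein kinase Chk2 (Homo sapiens), read by mobility shift assay, tested at 30 uM; a higher number here means more inhibition at the concentration tested (going by the name of the read-out), a lower number less inhibition. Within this small set compound 3 stands second highest of three numbers; its nearest neighbour is compound 1 `Cc1cc2c(c(N)nn2C)c(N2CCCCC2)n1`, which gives 4%, and the furthest is compound 2 `COCCNc1nc(C)cc2c1c(N)nn2C`, which gives -2%. All three measured steps lie within the scatter: a number 1 percentage points lower from compound 1 to compound 3 (within the scatter), a number 5 percentage points higher from compound 2 to compound 3 (within the scatter) and a number 6 percentage points lower from compound 1 to compound 2 (within the scatter), so the measured compounds show no separation from one another.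

Compound 4 `Cc1cc2[nH]nc(N)c2cn1` differs from compound 3 by hydrogen in place of methyl on an aromatic nitrogen. Among the compounds with values here, no measured step touches this position: the three steps recorded concern groups on an aromatic carbon, not the aromatic nitrogen of the five-membered ring, and none of them moved the read-out beyond the scatter. Within the data shown here, there is thus no precedent for either the size or the direction of this change, and the only guide is that every compound of the shared core measured so far gives a read-out within the scatter of the others. The expectation is therefore a step of no size beyond the scatter, no change at the digits printed from compound 3 to compound 4 (within the scatter). For compound 4 the estimated value in this assay is 3%, with a range from -7% to 13%.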

Compound 4, a percentage reported as inhibition, at one concentration (the size of the read-out at that concentration, not a potency): 7%
Compound 4: middle estimate off by 4 percentage points, on the low side, within the range that was stated.
By their numbers in this assay, from the lowest: compounds 2, 3, 1 and 4 (each within the scatter of the next).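

Within the data shown here, on the aromatic nitrogen of the five-membered ring, hydrogen in place of methyl gives in this assay a number 4 percentage points higher from compound 3 to compound 4 (within the scatter) and so provides the first measured step at this position, as the earlier steps all concerned groups on an aromatic carbon. The methyl on this nitrogen can therefore be removed without separating compound 4 from compound 3 at the single concentration tested, and the step gives no reliable direction for this change. No available information bears on the reason for this outcome.

Going by these compounds, whether a bulkier replacement on the same aromatic nitrogen, such as a longer alkyl chain like n-butyl or a benzyl group, would produce a step beyond the scatter remains open. Also open, on these data alone, is whether an amine-bearing chain at that nitrogen, or a carboxylic acid on the chain, would lift the read-out clear of the scatter, since a single replacement by hydrogen says little about how the position responds to groups larger than methyl.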